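This account rests on a few compounds, and the source may have more. Where it says the series, first, only, none or still open, it means among the compounds named here.

In a functional assay on MOLT-4 cells (Homo sapiens) for antiproliferative activity (a lower number here means a stronger inhibitor, a higher number a weaker inhibitor), the compounds measured so far give these values:

- compound 1 `COc1cc(C(=O)c2sc(-c3ccc(Br)cc3)cc2N)cc(OC)c1OC`: 92 nM
- compound 2 `COc1ccc(-c2cc(N)c(C(=O)c3cc(OC)c(OC)c(OC)c3)s2)cc1OC`: 20 nM
- compound 3 `COc1cc(C(=O)c2sc(-c3cccc([N+](=O)[O-])c3)cc2N)cc(OC)c1OC`: 7.5 nM

The three compounds share a core and differ only in the aryl group at one place. Compound 3, at 7.5 nM, has the lowest number of the three and is the strongest inhibitor among them. Compound 4 `COc1cc(C(=O)c2sc(-c3ccncc3)cc2N)cc(OC)c1OC` has pyridin-4-yl in place of 3-nitrophenyl on an aromatic carbon.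

Among the compounds with values here, all the measured steps bear on this change, as each swaps one aryl group for another at the same place. They are a 4.6-fold lower number from compound 1 to compound 2 (0.66 log units; beyond the scatter), a 2.7-fold lower number from compound 2 to compound 3 (0.43 log units; beyond the scatter) and a 12-fold lower number from compound 1 to compound 3 (1.09 log units; beyond the scatter), so they range from modest to large and all lie beyond the scatter. Within the data shown here, no measured compound carries pyridin-4-yl, so the data cannot fix the size of this step. Both other aryl groups give higher numbers than compound 3 does, so a modest to large rise in this assay is the expected direction, though with only these compounds this is a weak guide. The expected change is a 6.7-fold higher number from compound 3 to compound 4 (0.82 log units; beyond the scatter). For compound 4 the estimated value is 50 nM, with an expected range from 10 nM to 300 nM.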

Compound 4, half-maximal inhibitory concentration: 88 nM
Beside the measured number, compound 4's estimate is 1.8-fold (0.25 log units) below it; the range from low to high includes it.
By their numbers in this assay, from the lowest: compound 3; then compound 2; then compounds 4 and 1 (each within the scatter of the next).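

In this assay, the place next to the ring sulfur now carries a ring with a hetero atom, and pyridin-4-yl in place of 3-nitrophenyl gives a 12-fold higher number from compound 3 to compound 4 (1.07 log units; beyond the scatter), a large step, while pyridin-4-yl in place of 3,4-dimethoxyphenyl gives a 4.4-fold higher number from compound 2 to compound 4 (0.64 log units; beyond the scatter), a modest one. Set against 4-bromophenyl, pyridin-4-yl gives a 1.0-fold lower number from compound 1 to compound 4 (0.02 log units; within the scatter), so compound 1 and compound 4 cannot be told apart in this assay, and the nitrogen in the ring of compound 4 does not separate it from the carbon-only ring of compound 1. The data at hand offer no explanation for these differences between the aryl groups.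

The compounds shown leave open whether the place of the ring nitrogen matters, as pyridin-3-yl or pyridin-2-yl at this position would show. They also leave open whether the low number of compound 3 belongs to the nitro group itself or to where it sits on the ring, a question that 4-nitrophenyl, 3-aminophenyl or 3-cyanophenyl could address.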